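Three Aryl Groups Measured, a Fourth Awaits Its Number

The compounds below may be only part of what the source reports. "The series", "measured", "known", "first", "only" and "open" are said of these compounds alone.

Compound 1 `CCCS(=O)(=O)Nc1ccc(F)c(C(=O)c2n[nH]c3ncc(-c4cccc(F)c4)cc23)c1F`: 8.2% in an assay for binding affinity to dual specificity mitogen-activated protein kinase kinase 4 (Homo sapiens), read by KINOMEscan, tested at 100 nM; on this read-out lower numbers stand for a stronger effect and higher numbers for a weaker effect at the one concentration tested
Compound 2 `CCCS(=O)(=O)Nc1ccc(F)c(C(=O)c2n[nH]c3ncc(-c4ccccc4OC)cc23)c1F`: 1.9%
Compound 3 `CCCS(=O)(=O)Nc1ccc(F)c(C(=O)c2n[nH]c3ncc(-c4ccc(N)cc4)cc23)c1F`: 0.1%

All three share one core and differ only in the aromatic group attached to it. Compound 3 gives the lowest of the three numbers, yet the steps of a number 8.1 percentage points lower from compound 1 to compound 3 (within the scatter) and a number 1.8 percentage points lower from compound 2 to compound 3 (within the scatter) both lie within the scatter, as does a number 6.3 percentage points lower from compound 1 to compound 2 (within the scatter), so no ordering among them can be claimed.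

Compound 4 `CCCS(=O)(=O)Nc1ccc(F)c(C(=O)c2n[nH]c3ncc(-c4cccc(N(C)C)c4)cc23)c1F` is the next member. The change from compound 3 is 3-(dimethylamino)phenyl in place of 4-aminophenyl on an aromatic carbon. Within the data shown here, no measured step covers this exact swap, but every aryl swap seen so far stayed within the scatter in this assay, so compound 4 is expected to stay close to compound 3, with an estimated step of a number 2.9 percentage points higher from compound 3 to compound 4 (within the scatter). Compound 4 is therefore estimated at 3%, with a range from 0.2% to 15%.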

Compound 4, a percentage reported as activity, at one concentration (the size of the read-out at that concentration, not a potency): 26%
Beside the measured number, compound 4's estimate is 23 percentage points below it, outside the stated range (above it).
By their numbers in this assay, from the lowest: compounds 3, 2 and 1 (each within the scatter of the next); then compound 4.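

Read in this assay, the steps of a number 25.9 percentage points higher from compound 3 to compound 4 (beyond the scatter) and a number 24.1 percentage points higher from compound 2 to compound 4 (beyond the scatter) and a number 17.8 percentage points higher from compound 1 to compound 4 (beyond the scatter) show that this aromatic carbon does not accept every aryl group alike. The swap from 4-aminophenyl to 3-(dimethylamino)phenyl changes the place of the nitrogen on the ring, the heavy-atom count and the hydrogen-bond donor count all at once. Nothing measured here gives a reason for the higher number.

Which of these changes matters stays open. 3-Aminophenyl and 4-(dimethylamino)phenyl would pull the nitrogen's place apart from its two methyl groups.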